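A Second Change on the Ring Nitrogen

This account rests on a few compounds, and the source may have more. Where it says the series, first, only, none or still open, it means among the compounds named here.

In a functional assay on HOS-TE85 cells (Homo sapiens) for inhibition, read by CCK-8 assay, with a stated time of 72 h (on this read-out lower numbers stand for stronger inhibition and higher numbers for weaker inhibition), compound 1 (`CCN1C(=O)CSC1c1cccc(C(=O)NCCCCc2ccccc2)c1`) gives > 1000 nM as its result, which is a limit and not a number. Going by the values given here, compound 2 (`COc1cc(F)ccc1N1C(=O)CSC1c1cccc(C(=O)NCCCCc2ccccc2)c1`) gives 71.1 nM and is the only compound so far with a measured number. a group of 11 heavy atoms (8 carbon, 3 nitrogen; one five-membered aromatic ring with 3 hetero atoms, one six-membered aromatic ring of carbon only) in place of a group of 9 heavy atoms (7 carbon, 1 oxygen, 1 fluorine; one six-membered aromatic ring of carbon only), on an amide-type nitrogen in a ring is the change that leads from compound 2 to compound 3 (`O=C(NCCCCc1ccccc1)c1cccc(C2SCC(=O)N2c2cccc(-c3c[nH]nn3)c2)c1`). Among the compounds with values here, only one measured step bears on this nitrogen, the large at least 14-fold lower number from compound 1 to compound 2 (1.14 log units; beyond the scatter) on exchanging ethyl for 4-fluoro-2-methoxyphenyl. That step started from a group without an aromatic ring, whereas both groups here hold a six-membered aromatic ring of carbon only. A return to the weak end is therefore not expected, and a slightly higher number is the likelier direction. The expected shift is a 1.7-fold higher number from compound 2 to compound 3 (0.23 log units; within the scatter) by this estimate. For compound 3 the expected value is 120 nM within an estimated range of 25 nM to 600 nM in this assay overall.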

Compound 3, half-maximal inhibitory concentration: 110 nM
The estimate for compound 3 lay 1.1-fold (0.04 log units) above the measured number; the measured number falls inside the stated range.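

On the amide-type nitrogen in the ring, exchanging the 4-fluoro-2-methoxyphenyl group for the larger group with a five-membered aromatic ring with 3 hetero atoms gives a 1.5-fold higher number from compound 2 to compound 3 (0.19 log units; within the scatter), so no difference between the two groups can be read in this assay. Against ethyl, the new group also gives a clear gain, with an at least 9.0-fold lower number from compound 1 to compound 3 (0.95 log units; beyond the scatter). Compound 1 remains a limit and not a number: the limit of > 1000 nM in this assay, at which 1 of the 3 values shown sits.

The compounds shown leave open what a plain phenyl on this nitrogen would give, so the share of the six-membered aromatic ring cannot be separated from that of the five-membered ring. They also leave open whether a carboxylic acid or an amine in place of the five-membered ring would keep the number of compound 3.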